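Second trifluoromethyl on the urea aryl ring

The compounds below may be only part of what the source reports. "The series", "measured", "known", "first", "only" and "open" are said of these compounds alone.

For the measured compounds named here, compound 1 `COc1cc(-c2nn(-c3cccc(NC(=O)Nc4cc(C(F)(F)F)cc(C(F)(F)F)c4)c3)cc2-c2ccncc2)ccc1Cl` is the only member of the series with a numerical reading so far. In a functional assay on PC-3 cells (Homo sapiens) for inhibition, read by sulforhodamine B assay, with a stated time of 48 h (on this read-out lower numbers stand for stronger inhibition of growth and higher numbers for weaker inhibition of growth), compound 1 gives 2070 nM. Compound 2 `O=C(Nc1cccc(-n2cc(-c3ccncc3)c(-c3ccc(Cl)c(O)c3)n2)c1)Nc1ccc(Cl)c(Cl)c1` shares the core but differs at several places at once. In this assay compound 2 returns only > 32500 nM, which is a limit of the assay and not a number, and is the case described by the limit of > 32500 nM in this assay, at which 1 of the 2 values shown sits. Going by the values given here, no two measured compounds differ in a single place, so no measured step exists, and compound 1 stands alone as the one quantified point against which the next compound can be judged.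

Compound 3 `COc1cc(-c2nn(-c3cccc(NC(=O)Nc4cccc(C(F)(F)F)c4)c3)cc2-c2ccncc2)ccc1Cl` differs from compound 1 by one change: hydrogen in place of trifluoromethyl on an aromatic carbon. The urea aryl ring of compound 3 thus keeps a single trifluoromethyl group where compound 1 has two. Going from two such groups to one is expected to cost some potency in this assay, though the loss may be modest and could sit within the usual scatter. The expected step is a 2.2-fold higher number from compound 1 to compound 3 (0.34 log units; beyond the scatter). Compound 3 is therefore estimated at 4500 nM, with a range from 1500 nM to 15000 nM.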

Compound 3, concentration for total growth inhibition: 2510 nM
Beside the measured number, compound 3's estimate is 1.8-fold (0.25 log units) above it, within the range that was stated.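

In this assay, hydrogen in place of trifluoromethyl gives a 1.2-fold higher number from compound 1 to compound 3 (0.08 log units; within the scatter), so at this position on the urea aryl ring the two groups cannot be told apart by this read-out. For the compounds shown here, this is the first measured single-place step: compound 1 alone gave one quantified point but no measure of what this position contributes, whereas the pair shows that the second trifluoromethyl group is not required to keep growth inhibition at the level seen for compound 1. No measured property among the data shown bears on this step, and the result therefore stands without an explanation.

Going by these compounds, one step at one position cannot show whether the position is tolerant in general, and it remains open whether a nitrile, an amine or a carboxylic acid in place of this hydrogen would read the same as hydrogen and trifluoromethyl do. It also remains open whether the trifluoromethyl group retained in compound 3 matters to the reading in this assay, since no compound shown has that group replaced while the rest of compound 3 stays unchanged.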